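A few compounds are considered here, and "the series" means these few. Any claim that something is new, unique, unknown or untested is made for them only; others in the source may bear on it.

Compounds measured in an ADME assay on S9 fraction from liver (Homo sapiens) for metabolic stability, read by LC-MS, using NADPH, with stated times of 5 min and 60 min, tested at 5 uM; a lower number here means that less of the compound is left, a higher number that more of the compound is left:
Compound 1 `COc1ccc(COc2ccc(C3CN(C(=O)c4cc(OCCO)ccn4)C3)cc2OC)cc1`: 38%
Compound 2 `COc1cc(C2CN(C(=O)c3cc(OCCCC(=O)O)ccn3)C2)ccc1OCc1ccc(C2CC2)cc1`: 91%
Compound 3 `CCc1ccc(COc2ccc(C3CN(C(=O)c4cc(COC[C@@H](O)CO)ccn4)C3)cc2OC)cc1`: 54%

Of these three, compound 2 stands highest at 91%, and both other compounds lie lower by more than the usual scatter.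

Compound 4 `COc1cc(C2CN(C(=O)c3cc(COCC(CO)CO)ccn3)C2)ccc1OCc1ccc(C2CC2)cc1` keeps the rest of compound 2 and changes one side chain: (3-hydroxy-2-(hydroxymethyl)propoxy)methyl in place of 3-carboxypropoxy on an aromatic carbon. A (3-hydroxy-2-(hydroxymethyl)propoxy)methyl group takes the place of 3-carboxypropoxy on an aromatic carbon, opposite the ring nitrogen.

Among the measured compounds shown here, no measured pair differs at only one place, so the size of this step cannot be read directly from this assay. The closest guide is compound 3, whose side chain resembles the entering group and which gives 54%, although it also differs from compound 4 elsewhere. For the measured compounds named here, compound 2 is the only measured compound with 3-carboxypropoxy. A fall beyond the scatter is therefore expected, and the estimated step is a number 36 percentage points lower from compound 2 to compound 4 (beyond the scatter). For compound 4 the expected value is 55%, with an estimated range of 35% to 78%.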

Compound 4, percent of the compound remaining: 55%
Compound 4: middle estimate and measured number agree at the digits printed; low and high end bracket the measured number.
By their numbers in this assay, from the lowest: compound 1; then compounds 3 and 4 (each within the scatter of the next); then compound 2.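

In this assay, placing (3-hydroxy-2-(hydroxymethyl)propoxy)methyl instead of 3-carboxypropoxy on the aromatic carbon opposite the ring nitrogen gives a number 36 percentage points lower from compound 2 to compound 4 (beyond the scatter). Among the compounds shown here, this is the first pair here that differs in only one place, so it shows that this side chain alone can change the amount of compound left, with the rest of the molecule held constant. No measurement here gives a reason for the change.

One pair cannot separate the contribution of the carboxylic acid at the end of the leaving chain from that of the chain as a whole. It also leaves open how this position would respond to an amine at the end of the chain or to a shorter or longer carboxylic acid chain.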